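Swapping the Amide Ring for an Acylhydrazide Arm

The compounds below may be only part of what the source reports. "The series", "measured", "known", "first", "only" and "open" are said of these compounds alone.

The measured compounds, all sharing one core and differing only in the group on the amide-type nitrogen:

Compound 1 `COc1ccc2nc(C)cc(OCC(=O)Nc3c(C)cccc3C)c2c1` gives 112000 nM in a physicochemical assay for solubility, in phosphate buffer, measured as kinetic solubility, with a stated time of 1 h, at pH 7.4; on this read-out lower numbers stand for lower solubility and higher numbers for higher solubility.
Compound 2 `COc1cccc(NC(=O)COc2cc(C)nc3ccc(OC)cc23)c1` gives 35000 nM in this assay.
Compound 3 `COc1ccc2nc(C)cc(OCC(=O)Nc3cccnc3)c2c1` gives 32000 nM in this assay.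

Compound 3 holds the lowest of the three numbers. Its nearest neighbour is compound 2, where the step of a 1.1-fold lower number from compound 2 to compound 3 (0.04 log units; within the scatter) sits within the scatter, so the two cannot be ordered. Its furthest is compound 1, with a 3.5-fold lower number from compound 1 to compound 3 (0.54 log units; beyond the scatter).

Compound 4 `COc1ccc2nc(C)cc(OCC(=O)NNC(=O)c3ccncc3)c2c1` carries the change (((pyridin-4-yl)carbonyl)amino in place of pyridin-3-yl on an amide-type nitrogen). The measured steps all exchange one flat ring for another on that nitrogen: a 3.2-fold lower number from compound 1 to compound 2 (0.51 log units; beyond the scatter), a 3.5-fold lower number from compound 1 to compound 3 (0.54 log units; beyond the scatter) and a 1.1-fold lower number from compound 2 to compound 3 (0.04 log units; within the scatter). None of them introduces a ((pyridin-4-yl)carbonyl)amino group, so they bear on this step only loosely: they show that such exchanges have moved this assay by modest amounts or not at all. The step to compound 4 is therefore expected to be a 1.1-fold lower number from compound 3 to compound 4 (0.03 log units; within the scatter), with wide uncertainty. Compound 4 is estimated at 30000 nM, between 8000 nM and 120000 nM.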

Compound 4, solubility: >= 375000 nM
Compound 4 was reported as a limit; the forecaster's own chance of this, stated with the estimate: 5%; middle value at least 12-fold (1.09 log units) from the limit.
By their numbers in this assay, from the lowest: compounds 3 and 2 (each within the scatter of the next); then compound 1. At a limit, above all of these: compound 4.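

Until compound 4, the steps on the amide-type nitrogen only exchanged one six-membered aromatic ring for another, whereas ((pyridin-4-yl)carbonyl)amino adds a carbonyl and brings 1 hydrogen-bond donor where pyridin-3-yl has 0. In this assay, compound 4 is reported only as a limit, not as an exact number: the limit of >= 375000 nM in this assay, at which 1 of the 4 values shown sits. Even so, this position carries a much larger step than the ring exchanges did, with an at least 11-fold higher number from compound 3 to compound 4 (1.06 log units; beyond the scatter), an at least 10-fold higher number from compound 2 to compound 4 (1.02 log units; beyond the scatter) and an at least 3.3-fold higher number from compound 1 to compound 4 (0.52 log units; beyond the scatter).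

As far as these compounds go, the full size of these steps remains unknown, and the carbonyl, the added nitrogen and the pyridin-4-yl ring cannot be told apart as the source of the change. From the compounds shown here alone, it also remains open where a benzoylamino group, with a plain benzene ring in place of the pyridine, or a carboxylic acid on that ring would fall.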